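A few compounds are considered here, and "the series" means these few. Any claim that something is new, unique, unknown or untested is made for them only; others in the source may bear on it.

Compound 2 `COC(=O)CCC(=O)N[C@@H](C)C(=O)N[C@@H](C)C(=O)N1CCC[C@H]1C(=O)N[C@H](C(=O)C(F)(F)F)C(C)C` gives 14 nM in an assay on isolated protein for binding affinity to chymotrypsin-like elastase family member 1 (Homo sapiens) (on this read-out higher numbers stand for weaker inhibition and lower numbers for stronger inhibition), the lowest of the three numbers measured. Compound 1 `CC(C)[C@H](NC(=O)[C@@H]1CCCN1C(=O)[C@H](C)NC(=O)[C@H](C)NC(=O)OC(C)(C)C)C(=O)C(F)(F)F` gives 44 nM, and compound 3 `COC(=O)C(=O)[C@H](C)NC(=O)[C@@H]1CCCN1C(=O)[C@H](C)NC(=O)[C@@H]1CCCN1C(C)=O` gives 850 nM. Among the compounds with values here, the only step measured in one place is a 3.1-fold lower number from compound 1 to compound 2 (0.50 log units; beyond the scatter), which concerns the cap at the other end of the chain and does not touch the part that changes here.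

Compound 4 `COC(=O)CCC(=O)N[C@@H](C)C(=O)N[C@@H](C)C(=O)N1CCC[C@H]1C(=O)N[C@H](C(=O)C(=O)OC)C(C)C` differs from compound 2 by methoxycarbonyl in place of trifluoromethyl on a carbonyl carbon. Within the data shown here, no measured step tracks this exchange directly. Compound 3 carries the same methoxycarbonyl on a carbonyl carbon but differs from compound 2 in more than one place, so its value only shows that a compound of that kind sits at a weaker level.

Given this, a weakening step is expected for compound 4, a 4.3-fold higher number from compound 2 to compound 4 (0.63 log units; beyond the scatter), with wide uncertainty. Compound 4 is therefore estimated at 60 nM in this assay, within a range from 10 nM to 400 nM.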

Compound 4, inhibition constant: 200 nM
Estimate against measurement, compound 4: 3.3-fold (0.52 log units) below; low and high end bracket the measured number.
By their numbers in this assay, from the lowest: compound 2; then compound 1; then compound 4; then compound 3.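

In this assay, the exchange on this carbonyl carbon now has a measured size: with the rest of the molecule unchanged, methoxycarbonyl in place of trifluoromethyl gives a 14-fold higher number from compound 2 to compound 4 (1.15 log units; beyond the scatter), a large step. Within the data shown here, the only other step available, a 3.1-fold lower number from compound 1 to compound 2 (0.50 log units; beyond the scatter), is modest and lies at the cap at the other end of the chain, so in this small set the group on the carbonyl carbon moves the number more than that cap exchange does. Nothing measured here explains why the step is this large.

On these data alone, whether a carboxylic acid or an ethoxycarbonyl group on the same carbonyl carbon would sit nearer to trifluoromethyl or to methoxycarbonyl remains open. So does whether the exchange gives a similar step with the tert-butoxy cap of compound 1.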